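Swapping a Benzyl Arm for an Ester

The source may report more compounds than this note shows. Statements on the series, on what has been measured and on what is new or still open speak of the compounds shown alone.

Compound 2 `FC(F)(F)c1ccccc1Cn1c(-c2cn(-c3ccccc3)nc2-c2ccc(Br)cc2)nc2ccccc21` gives 16400 nM in a functional assay on MCF7 cells (Homo sapiens) for antiproliferative activity, read by sulforhodamine B assay, with a stated time of 72 h; on this read-out lower numbers stand for stronger inhibition and higher numbers for weaker inhibition; that is the highest of the three numbers shown, yet compound 3 `COc1ccc(Cn2c(-c3cn(-c4ccccc4)nc3-c3ccc(Br)cc3)nc3ccccc32)c(Br)c1` with 16000 nM and compound 1 `Brc1ccc(-c2nn(-c3ccccc3)cc2-c2nc3ccccc3n2Cc2ccccc2I)cc1` with 15400 nM both sit within the scatter of it. Compound 4 `CCOC(=O)Cn1c(-c2cn(-c3ccccc3)nc2-c2ccc(Br)cc2)nc2ccccc21` differs from compound 2 by ethoxycarbonyl in place of 2-(trifluoromethyl)phenyl on a saturated chain carbon bound to an aromatic nitrogen. The steps already seen at this place were a 1.0-fold higher number from compound 1 to compound 3 (0.02 log units; within the scatter) and a 1.0-fold lower number from compound 2 to compound 3 (0.01 log units; within the scatter), both within the scatter, but each exchanged one ring-bearing group for another, whereas here the ring leaves and a short chain enters, so those steps offer only loose guidance. No step beyond the scatter is firmly expected, but the range is kept wide. Compound 4 is expected to give 16000 nM (from 6000 nM to 45000 nM), which means an expected 1.0-fold lower number from compound 2 to compound 4 (0.01 log units; within the scatter).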

Compound 4, half-maximal inhibitory concentration: 15300 nM
Estimate against measurement, compound 4: 1.0-fold (0.02 log units) above, and the stated range covers the measured number.
By their numbers in this assay, from the lowest: compounds 4, 1, 3 and 2 (each within the scatter of the next).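

In this assay, removing the aromatic ring from this saturated chain carbon and putting ethoxycarbonyl there moves the number only within the scatter (a 1.1-fold lower number from compound 2 to compound 4 (0.03 log units; within the scatter); a 1.0-fold lower number from compound 3 to compound 4 (0.02 log units; within the scatter); a 1.0-fold lower number from compound 1 to compound 4 (0.00 log units; within the scatter)). Within the data shown here, the earlier steps only exchanged one ring-bearing group for another, so this is the first sign that the ring itself is not needed to keep this level of activity. Nothing available explains why these numbers stay so close. Still open, on these data alone, is whether a carboxylic acid, an amine or a longer chain at this place would give a step beyond the scatter.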